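Swapping the aryl group on a sulfonamide scaffold

This account rests on a few compounds, and the source may have more. Where it says the series, first, only, none or still open, it means among the compounds named here.

Of the compounds shown here, three sharing a sulfonamide core have been measured in a functional assay on DLD-1 cells (Homo sapiens) for antiproliferative activity, read by CellTiter-Glo, with a stated time of 72 h; on this read-out higher numbers stand for weaker inhibition and lower numbers for stronger inhibition. Compound 2 `Cc1ccc(S(=O)(=O)N2CCC(N3CCC(C)CC3)CC2)cc1C` gives 24 nM, the lowest number of the three. Compound 1 `Cc1cc(C)c(S(=O)(=O)N2CCC(N3CCC(O)CC3)CC2)c(C)c1` gives 106 nM in this assay, and compound 3 `COc1ccc(-c2ccc(S(=O)(=O)N3CCC(N4CCC(C)CC4)CC3)cc2)cc1` gives 263 nM; both gaps to compound 2 lie beyond the usual scatter, so compound 2 stands as the strongest inhibitor among the measured compounds. For the measured compounds named here, compound 1 and compound 3 each differ from compound 2 in more than one place, so no single-change step among the measured compounds can be read off.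

Compound 4 `CC1CCN(C2CCN(S(=O)(=O)c3ccc(Cl)nc3)CC2)CC1` has not yet been measured. It differs from compound 2 by 6-chloropyridin-3-yl in place of 3,4-dimethylphenyl on a sulfonyl sulfur. Within this set, the only other variation at the sulfonyl sulfur is found in compound 3, which gives a higher number in this assay than compound 2, but that change is of a different kind, so there is no direct guide for the present one. The expectation is that compound 4 will give a somewhat higher number than compound 2, with the step of a 2.9-fold higher number from compound 2 to compound 4 (0.46 log units; beyond the scatter) expected to be modest and possibly within the scatter. Compound 4 is estimated at 70 nM, within a range from 25 nM to 250 nM.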

Compound 4, half-maximal inhibitory concentration: 3700 nM
Beside the measured number, compound 4's estimate is 53-fold (1.72 log units) below it, outside the stated range (above it).
By their numbers in this assay, from the lowest: compound 2; then compound 1; then compound 3; then compound 4.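

The group on the sulfonyl sulfur turns out to matter greatly: in this assay, exchanging 3,4-dimethylphenyl for 6-chloropyridin-3-yl gives a 150-fold higher number from compound 2 to compound 4 (2.19 log units; beyond the scatter), a large weakening from one change with the rest of the molecule left intact. For the compounds shown here, this is the first step in the set that isolates this position, and it shows that keeping a six-membered aromatic ring there is not enough to preserve strong inhibition, even though the two groups are close in heavy-atom count. No measurement available here explains why the number rises so sharply.

The exchange alters several things at once, adding a ring nitrogen with its hydrogen-bond acceptor and replacing two methyl groups with a chlorine, so the compounds shown cannot say which of these drives the step. A 4-chlorophenyl group would keep the chlorine without the ring nitrogen, and a 6-methylpyridin-3-yl group would keep the ring nitrogen without the chlorine, so the pair could begin to separate the two contributions.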